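The source may report more compounds than this note shows. Statements on the series, on what has been measured and on what is new or still open speak of the compounds shown alone.

Measured so far:
compound 1 `O=c1cc(Cc2c(F)cccc2F)nc(SCc2ccccc2)[nH]1`: > 73000 nM
compound 2 `Cc1c(Cc2c(F)cccc2F)nc(SCc2ccccc2)[nH]c1=O`: > 70000 nM
compound 3 `CC(C)Sc1nc(Cc2c(F)cccc2F)cc(=O)[nH]1`: > 84000 nM

Each of these values is a limit of an ADME assay on MT4 cells (Homo sapiens) for cytotoxicity, read by MTT assay (a higher number here means that more compound is tolerated, a lower number that less compound is tolerated), not a number. Compound 1 reaches only a limit, (the limit of > 73000 nM in this assay, at which 1 of the 3 values shown sits). Compound 2 likewise sits at a limit, (the limit of > 70000 nM in this assay, at which 1 of the 3 values shown sits). Compound 3 also stops at a limit, (the limit of > 84000 nM in this assay, at which 1 of the 3 values shown sits). Compound 1 and compound 2 differ by methyl in place of hydrogen on an aromatic carbon, and the step is a step that the two limits leave unreadable from compound 1 to compound 2. Compound 1 and compound 3 differ in their cores by isopropyl in place of benzyl on a sulfur, giving a step that the two limits leave unreadable from compound 1 to compound 3.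

Compound 4 `Cc1c(Cc2c(F)cccc2F)nc(SC(C)C)[nH]c1=O` is not yet measured. It differs from compound 3 by methyl in place of hydrogen on an aromatic carbon. This is the same kind of change as that from compound 1 to compound 2, though the surroundings differ: in compound 1 the place is para to a benzylsulfanyl group (8 heavy atoms), in compound 3 it is para to an isopropylsulfanyl group (4 heavy atoms).

In this assay compound 4 is expected to remain at a limit, so the expected step is a step that the limit leaves unreadable from compound 3 to compound 4, resting on compound 3 at > 84000 nM and on the unreadable step from compound 1 to compound 2. The estimate for compound 4 is 100000 nM, expected between 40000 nM and 300000 nM.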

Compound 4, half-maximal cytotoxic concentration: > 77000 nM
Compound 4: only a limit was reported (the forecaster's own chance of this, stated with the estimate: 85%); the middle value lies beyond the limit too.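

In this assay compound 4 gives > 77000 nM which is a limit and not a number. Neither the step from compound 3 to compound 4 nor the step from compound 2 to compound 4 can be read, as each joins two limits. The compounds shown leave open at what concentration any of these four compounds harms the cells.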